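This account rests on a few compounds, and the source may have more. Where it says the series, first, only, none or still open, it means among the compounds named here.

Measured compounds, antiproliferative read-out:

Compound 1 `O=C(/C=C\Nc1ccc(F)cc1)c1cn(-c2ccccc2)nc1-c1ccccc1` gives 34200 nM in an ADME assay on HaCaT cells (Homo sapiens) for antiproliferative activity, read by MTT assay, with a stated time of 48 h; a higher number here means a weaker inhibitor, a lower number a stronger inhibitor.
Compound 2 `O=C(/C=C\Nc1ccc(C(F)(F)F)cc1)c1cn(-c2ccccc2)nc1-c1ccccc1` gives > 50000 nM in this assay, a limit of the assay rather than a number.
Compound 3 `COc1ccc(N/C=C\C(=O)c2cn(-c3ccccc3)nc2-c2ccccc2)cc1` gives > 50000 nM in this assay, again a limit and not a number.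

Compound 2 therefore stands at the upper edge of what this assay reports, with no number of its own; the same holds for compound 3, so that (the limit of > 50000 nM in this assay, at which 2 of the 3 values shown sit).

The unmeasured compound 4 `O=C(/C=C\Nc1ccc(C(F)(F)F)cc1)c1cn(-c2ccccc2)nc1-c1ccc(Cl)cc1` differs from compound 2 by chloro in place of hydrogen on an aromatic carbon. The measured steps touch a different ring: an at least 1.4-fold higher number from compound 1 to compound 2 (0.16 log units; that floor lies within the scatter) and an at least 1.4-fold higher number from compound 1 to compound 3 (0.16 log units; that floor lies within the scatter) both alter the anilino ring, and both end at a limit, while the step from compound 2 to compound 3 cannot be read from two limits. No measured step alters the phenyl on the core, so nothing shown bears directly on the change from compound 2 to compound 4.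

Given that compound 2 already sits at the limit, compound 4 is expected to stay at or near that limit, most likely reported as a limit again. Compound 4 is estimated at 50000 nM, with a range from 20000 nM to 120000 nM. The step from compound 2 to compound 4 is accordingly estimated as a number no higher from compound 2 to compound 4 (the limit leaves the size open), which is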

Compound 4, half-maximal inhibitory concentration: > 50000 nM
Compound 4 was reported as a limit; the forecaster's own chance of this, stated with the estimate: 65%; the middle value lies on the limit itself.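

Compound 2 and compound 4 both stand at a limit and not at a number, so no step can be read between them, and the chloro in place of hydrogen shows no readable effect: the limit of > 50000 nM in this assay, at which 3 of the 4 values shown sit.

Still open, as far as these compounds go, is what phenyl to 4-chlorophenyl does in this assay on a compound with a readable number, and how compound 2, compound 3 and compound 4 rank among themselves.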